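Swapping Cyclopropyl for Thiophen-2-yl: An Expected Step

This account rests on a few compounds, and the source may have more. Where it says the series, first, only, none or still open, it means among the compounds named here.

Measured in a functional assay on the whole organism (plasma, strain Sprague-Dawley) with Rattus norvegicus as the target, with a stated time of 2 h, at a dose of 25 mg/kg by the oral route; a higher number here means a stronger effect of the compound at the dose given, a lower number a weaker effect:
- compound 1 `c1ccc(C(/N=C2\CCCCCN2)C2CC2)cc1` gives 18%
- compound 2 `c1ccc(C(/N=C2\CCCCCCN2)C2CC2)cc1` gives 26%
- compound 3 `c1ccc(C(/N=C2\CCCCCN2)c2cccs2)cc1` gives 36%

Compound 2 sits within the usual scatter of both compound 1 and compound 3, so the three numbers cannot be ranked with confidence. The unmeasured compound 4 `c1ccc(C(/N=C2\CCCCCCN2)c2cccs2)cc1` differs from compound 2 in one place: thiophen-2-yl in place of cyclopropyl on a saturated chain carbon bound to an aromatic carbon and a double-bonded nitrogen. The same exchange has been seen once before, in a number 18 percentage points higher from compound 1 to compound 3 (beyond the scatter), a modest rise beyond the scatter. On that single precedent a similar upward step is expected for compound 4 in this assay, though one step is thin evidence. Compound 4 is therefore estimated at 42%, with a range from 26% to 58%, meaning an expected step of a number 16 percentage points higher from compound 2 to compound 4 (beyond the scatter).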

Compound 4, a percentage reported as inhibition, in the whole organism at one dose (the size of the read-out at that dose, not a potency): 37%
Estimate against measurement, compound 4: 5 percentage points above; measured number inside the range.
By their numbers in this assay, from the lowest: compounds 1, 2, 3 and 4 (each within the scatter of the next, the first and the last beyond it).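

The step of a number 11 percentage points higher from compound 2 to compound 4 (beyond the scatter) shows that thiophen-2-yl in place of cyclopropyl raises the number in this assay on a second core, so the earlier rise no longer stands alone. The two steps agree in direction and, within the scatter, in size: the same change on two cores in this assay, a number 18 percentage points higher (beyond the scatter) from compound 1 to compound 3 and a number 11 percentage points higher (beyond the scatter) from compound 2 to compound 4, 7 percentage points apart, within the scatter of two such steps

The compounds shown leave open how a furan-2-yl ring, an amine or a longer chain would behave on this saturated chain carbon bound to an aromatic carbon and a double-bonded nitrogen. They also cannot tell why this change raises the number on both cores.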